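This account rests on a few compounds, and the source may have more. Where it says the series, first, only, none or still open, it means among the compounds named here.

compound 1 `COc1ccc(O)c(C2=N[C@@](C)(C(=O)O)CS2)c1` gives -0.61
compound 2 `C[C@]1(C(=O)O)CSC(c2ccc(O)cc2O)=N1` gives -1.05
compound 3 `COc1ccc(C2=N[C@@](C)(C(=O)O)CS2)c(O)c1OC` gives -0.95

These three values come from a physicochemical assay for lipophilicity (on this read-out higher numbers stand for higher lipophilicity and lower numbers for lower lipophilicity), and the compounds share a common core. Compound 3 stands within the scatter of compound 2 and clearly under compound 1, a gap beyond the scatter. The next compound to be measured is compound 4 `COc1ccc(C2=N[C@@](C)(C(=O)O)CS2)c(O)c1` and it differs from compound 3 by a single change hydrogen in place of methoxy on an aromatic carbon that puts hydrogen in place of methoxy on an aromatic carbon, ortho to a hydroxy group and ortho to a methoxy group. Among the measured compounds shown here, no measured pair shows this change directly, so the expectation rests on indirect evidence. Compound 4 carries the same groups as compound 1 (at -0.61) in a different arrangement, which suggests a value nearer to that one. A small upward move in this assay is therefore expected, and the estimated a number 0.20 log units higher from compound 3 to compound 4 (within the scatter) would not clearly exceed the scatter. For compound 4 the expected value is -0.75 within an estimated range from -1 to -0.5 in the same read-out.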

Compound 4, partition coefficient: -0.7
The estimate for compound 4 lay 0.05 log units below the measured number; the range from low to high includes it.
By their numbers in this assay, from the lowest: compounds 2, 3, 4 and 1 (each within the scatter of the next, the first and the last beyond it).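

In this assay, hydrogen in place of methoxy on an aromatic carbon, ortho to a hydroxy group and ortho to a methoxy group, gives a number 0.25 log units higher from compound 3 to compound 4 (within the scatter) and so separates the two groups at this position by no clear margin. Methyl in place of hydrogen on an oxygen on the aromatic ring gives a number 0.35 log units higher from compound 2 to compound 4 (beyond the scatter) as a modest step, the only one of the two beyond the scatter. Nothing shown here explains either step.

Each change appears only once, so the compounds shown leave open whether either result would hold on another substitution pattern. They also leave open how an amine or a fluorine would read at the same aromatic carbon, and how a longer chain would read on that oxygen.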